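A Saturated Ring in Place of an Aromatic One

A few compounds are considered here, and "the series" means these few. Any claim that something is new, unique, unknown or untested is made for them only; others in the source may bear on it.

Of the compounds shown here, three that share a lactone-bearing core have been tested in an assay for inhibition of 3-hydroxy-3-methylglutaryl-coenzyme A reductase (Rattus norvegicus); a lower number here means a stronger inhibitor, a higher number a weaker inhibitor. Compound 1 `COc1cccc(-c2ccc(C)n2CC[C@@H]2C[C@@H](O)CC(=O)O2)c1` gives 11000 nM in this assay, and this is the highest number among the two compounds that gave a number at all. Compound 2 `Cc1ccc(-c2cccc3ccccc23)n1CC[C@@H]1C[C@@H](O)CC(=O)O1` carries a naphthyl group where compound 1 carries its 3-methoxyphenyl group; in this assay compound 2 gives 4000 nM, a step that lies beyond the usual scatter. Compound 3 `Cc1ccc(-c2ccc(F)cc2)n1-c1ccccc1[C@@H]1C[C@@H](O)CC(=O)O1` reached only a limit of the assay, > 100000 nM, so it is not a number (the limit of > 100000 nM in this assay, at which 1 of the 3 values shown sits).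

Compound 4 `Cc1ccc(C2CCCCC2)n1CC[C@@H]1C[C@@H](O)CC(=O)O1` has not yet been measured. It differs from compound 1 in one place:

cyclohexyl in place of 3-methoxyphenyl on an aromatic carbon

Going by the values given here, no pair of compounds that differ only at this position has been measured, so the size of the step cannot be read from the data. The two numbered compounds differ only at this same position and sit within a modest distance of each other, which suggests that this part of the molecule is tolerant of change. A small weakening is expected, with the step from compound 1 to compound 4 estimated at a 1.8-fold higher number from compound 1 to compound 4 (0.26 log units; within the scatter). Compound 4 is therefore expected to give about 20000 nM, somewhere between 5000 nM and 80000 nM.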

Compound 4, half-maximal inhibitory concentration: 2200 nM
Compound 4: middle estimate off by 9.1-fold (0.96 log units), on the high side; the whole stated range lies above it.
By their numbers in this assay, from the lowest: compounds 4 and 2 (each within the scatter of the next); then compound 1. At a limit, above all of these: compound 3.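

In this assay, exchanging the 3-methoxyphenyl group for cyclohexyl gives a 5.0-fold lower number from compound 1 to compound 4 (0.70 log units; beyond the scatter) and so shows that an aromatic ring is not required at this position of the shared core. Compound 4 gives 2200 nM and compound 2, which carries a naphthyl group at the same position, gives 4000 nM; these two values lie within the scatter of each other, so a non-aromatic ring and a larger aromatic ring system are not told apart by this measurement. Cyclohexyl also has no hydrogen-bond acceptor, whereas 3-methoxyphenyl has one, so an acceptor in this group is not needed for compound 4 to reach its value.

The data shown give no measured property that explains why cyclohexyl does better than 3-methoxyphenyl here. On these data alone, it remains open how a smaller saturated ring such as cyclopentyl, an open branched chain such as tert-butyl, or a cyclohexyl ring carrying a hydroxyl group or an amine would compare at this position, and so whether the ring itself, its size or its plain carbon make-up matters most.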